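A few compounds are considered here, and "the series" means these few. Any claim that something is new, unique, unknown or untested is made for them only; others in the source may bear on it.

Measured compounds:
compound 1 `Cc1ccc(NC(=S)NC(=O)c2ccc(OCc3cccc(Cl)c3)cc2)cc1-c1nc2ccccc2[nH]1` — 51300 nM
compound 2 `Cc1ccc(NC(=S)NC(=O)c2ccc(OCc3cccc(Cl)c3Cl)cc2)cc1-c1nc2ccccc2[nH]1` — > 100000 nM
compound 3 `Cc1ccc(NC(=S)NC(=O)c2ccc(OCc3ccc(Cl)c(Cl)c3)cc2)cc1-c1nc2ccccc2[nH]1` — 6390 nM

In a functional assay on MGC-803 cells (Homo sapiens) for inhibition, read by MTT assay, with a stated time of 48 h (on this read-out lower numbers stand for stronger inhibition and higher numbers for weaker inhibition), compound 3 holds the lowest number shown; compound 1 stands nearest, at an 8.0-fold lower number from compound 1 to compound 3 (0.90 log units; beyond the scatter) reversed. Compound 2 returns only the assay limit (the limit of > 100000 nM in this assay, at which 1 of the 3 values shown sits). Compound 4 `O=C(NC(=S)Nc1ccc(Cl)c(-c2nc3ccccc3[nH]2)c1)c1ccc(OCc2ccc(Cl)c(Cl)c2)cc1` differs from compound 3 by chloro in place of methyl on an aromatic carbon. The measured steps, an 8.0-fold lower number from compound 1 to compound 3 (0.90 log units; beyond the scatter), an at least 1.9-fold higher number from compound 1 to compound 2 (0.28 log units; that floor lies within the scatter) and an at least 15-fold lower number from compound 2 to compound 3 (1.19 log units; beyond the scatter), all concern the ring bearing the chlorines, not the ring changed here, so none bears directly on the step to compound 4. With no evidence pointing either way, compound 4 is expected to stay close to compound 3, with a 1.0-fold higher number from compound 3 to compound 4 (0.01 log units; within the scatter) within the scatter. The estimate for compound 4 in this assay is 6500 nM, between 2000 nM and 20000 nM.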

Compound 4, half-maximal inhibitory concentration: 5170 nM
Compound 4: the middle estimate sits 1.3-fold (0.10 log units) above what was measured; low and high end bracket the measured number.
By their numbers in this assay, from the lowest: compounds 4 and 3 (each within the scatter of the next); then compound 1. At a limit, above all of these: compound 2.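

In this assay the position ortho to the 1H-benzimidazol-2-yl group accepts chloro in place of methyl with no readable change (a 1.2-fold lower number from compound 3 to compound 4 (0.09 log units; within the scatter)). This is the first step shown on this ring, and unlike the step on the ring bearing the chlorines (an 8.0-fold lower number from compound 1 to compound 3 (0.90 log units; beyond the scatter)), it stays within the scatter. Nothing measured here accounts for this result.

On these data alone, whether this position would accept a methoxy group, an amine or a carboxylic acid stays open. So does whether plain hydrogen there would give a similar number.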